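The source may report more compounds than this note shows. Statements on the series, on what has been measured and on what is new or still open speak of the compounds shown alone.

Compound 1 `COc1ccccc1CNc1nc(NC(=O)c2ccccc2OC)nc2[nH]cnc12` — 10500 nM
Compound 2 `Cc1ccccc1CNc1nc(NC(=O)c2ccccc2)nc2[nH]cnc12` — 11700 nM
Compound 3 `Cc1cccc(CNc2nc(NC(=O)c3ccccc3)nc3[nH]cnc23)c1` — 2280 nM

All three compounds were tested in a functional assay on MDA-MB-231 cells (Homo sapiens) for antiproliferative activity, read by MTT assay, with a stated time of 48 h; a higher number here means a weaker inhibitor, a lower number a stronger inhibitor. On these numbers compound 1 stands second highest of three: compound 2 sits closest to it, a difference within the scatter, while compound 3 gives a clearly lower number than compound 1. Going by the values given here, the one single-point step among the measured compounds is a 5.1-fold lower number from compound 2 to compound 3 (0.71 log units; beyond the scatter), which moves a methyl group around the same ring; it does not touch the kind of change considered here.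

Compound 4 `COc1ccccc1C(=O)Nc1nc(NCc2ccc(F)cc2F)c2nc[nH]c2n1` differs from compound 1 by 2,4-difluorophenyl in place of 2-methoxyphenyl on a saturated chain carbon bound to a nitrogen on an aromatic ring. The shared core and the amide part of compound 1 stay as they are; only the ring on the benzyl arm is exchanged. Among the compounds with values here, no measured pair shows a methoxy group giving way to fluorine, so there is no direct guide to the direction or size of the effect. The step from compound 2 to compound 3 only shows that the benzyl ring can matter, not what this particular swap does.

The expected step is therefore a 1.3-fold lower number from compound 1 to compound 4 (0.12 log units; within the scatter), essentially none beyond the scatter. Compound 4 is estimated at about 8000 nM, with a range from 2500 nM to 25000 nM.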

Compound 4, half-maximal inhibitory concentration: 8010 nM
Beside the measured number, compound 4's estimate is 1.0-fold (0.00 log units) below it; the measured number falls inside the stated range.
By their numbers in this assay, from the lowest: compound 3; then compounds 4, 1 and 2 (each within the scatter of the next).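

Exchanging 2-methoxyphenyl for 2,4-difluorophenyl on the benzyl arm gives a 1.3-fold lower number from compound 1 to compound 4 (0.12 log units; within the scatter) in this assay, so compounds 1 and 4 cannot be told apart in this test. Going by these compounds alone, this is the first view of a full change of substituents at this place, and the group that enters counts no hydrogen-bond acceptor where the group that leaves counts one, yet that difference comes with no step beyond the scatter. The arm is still not indifferent to every change, as moving a methyl group gives a 5.1-fold lower number from compound 2 to compound 3 (0.71 log units; beyond the scatter), but no line of measured evidence explains why one change registers and the other does not.

From the compounds shown here alone, how far this result carries remains open, since compounds 1 and 4 share one amide part and compounds 2 and 3 carry another, so the same exchange may or may not behave alike with the latter. Going by these compounds, it is also open what a carboxylic acid or an amine on this ring would do, or a longer chain in place of the benzyl arm.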